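Naphthalene sulfonamide in place of a chlorinated bicyclic group

The compounds below may be only part of what the source reports. "The series", "measured", "known", "first", "only" and "open" are said of these compounds alone.

Measured so far:
Compound 1 `CN(C)CCn1ccc2c(NS(=O)(=O)c3ccc4ccccc4c3)cccc21` with 14.9 nM
Compound 2 `CCN(CC)CCn1ccc2cc(NS(=O)(=O)c3c(Cl)nc4sccn34)ccc21` with 97.3 nM

Of the compounds shown here, two have been measured in an assay on HEK293 cells for binding affinity to 5-hydroxytryptamine receptor 6 (Homo sapiens); on this read-out lower numbers stand for stronger inhibition and higher numbers for weaker inhibition. Compound 1 `CN(C)CCn1ccc2c(NS(=O)(=O)c3ccc4ccccc4c3)cccc21` gives 14.9 nM. Compound 2 `CCN(CC)CCn1ccc2cc(NS(=O)(=O)c3c(Cl)nc4sccn34)ccc21` gives 97.3 nM, which is the higher of the two numbers, and the gap between compound 2 and compound 1 lies beyond the usual scatter.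

Compound 3 `CCN(CC)CCn1ccc2cc(NS(=O)(=O)c3ccc4ccccc4c3)ccc21` has not yet been measured. It differs from compound 2 in one place: a group of 10 heavy atoms (10 carbon; 2 six-membered aromatic rings of carbon only) in place of a group of 9 heavy atoms (5 carbon, 2 nitrogen, 1 sulfur, 1 chlorine; 2 five-membered aromatic rings with 2 hetero atoms each), on a sulfonyl sulfur. For the measured compounds named here, the sulfonyl group that enters is the same one that compound 1 carries, although compound 1 and compound 3 differ elsewhere, so no single step joins them and their numbers only suggest a direction.

A step of moderate size toward a lower number is expected in this assay, beyond the scatter, since the naphthalen-2-yl sulfonamide of compound 1 gives 14.9 nM. For compound 3 the estimate is 25 nM, within a range from 6 nM to 100 nM, which corresponds to an expected step of a 3.9-fold lower number from compound 2 to compound 3 (0.59 log units; beyond the scatter).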

Compound 3, inhibition constant: 141 nM
Compound 3: the middle estimate sits 5.6-fold (0.75 log units) below what was measured; the measured number lies above the stated range.
By their numbers in this assay, from the lowest: compound 1; then compounds 2 and 3 (each within the scatter of the next).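

In this assay, placing naphthalen-2-yl on the sulfonyl sulfur, where compound 2 carries its chlorinated bicyclic group, gives a 1.4-fold higher number from compound 2 to compound 3 (0.16 log units; within the scatter). On this core, the read-out therefore does not separate two groups of quite different make-up: one has only carbon atoms and no hydrogen-bond acceptors, while the other has chlorine, sulfur, two nitrogens and three hydrogen-bond acceptors, so neither the chlorine nor those hetero atoms are needed to hold the number at this level. Nothing available here accounts for this outcome.

Compound 1 shares the naphthalen-2-yl sulfonyl group with compound 3 but differs from it elsewhere, so the compounds shown cannot say which of those other differences goes with the values of the two compounds. They also leave open whether a smaller carbon-only group such as phenyl, or a phenyl ring bearing a single chlorine, would read the same on the sulfonyl sulfur of this core, and what a pyrrolidine would do in place of the diethylamine.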